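Thiophene in place of phenyl on a ribosylated bicyclic core

The source may hold more compounds than are shown below. What is called first, only, known or untested is meant among the compounds shown, and "the series" means these compounds.

Compound 2 `COc1ncnc2c1c(-c1ccccc1)cn2[C@@H]1O[C@H](CO)[C@@H](O)[C@H]1O` carries a phenyl and a methoxy group on the shared core. In a functional assay on HCT-116 cells (Homo sapiens), read by MTT assay, with a stated time of 72 h (on this read-out higher numbers stand for weaker inhibition and lower numbers for stronger inhibition), compound 2 reaches only the limit > 20000 nM. Compound 1 `COc1ncnc2c1c(-c1cccs1)cn2[C@@H]1O[C@H](CO)[C@@H](O)[C@H]1O` differs by thiophen-2-yl in place of phenyl on an aromatic carbon and in this assay gives 440 nM, which is an at least 45-fold lower number from compound 2 to compound 1 (1.65 log units; beyond the scatter). Compound 3 `CNc1ncnc2c1c(-c1ccccc1)cn2[C@@H]1O[C@H](CO)[C@@H](O)[C@H]1O` differs from compound 2 by methylamino in place of methoxy on an aromatic carbon; compound 3 also returns only a limit, > 100000 nM, so the step that the two limits leave unreadable from compound 2 to compound 3 stays unreadable. Compound 4 `CNc1ncnc2c1c(-c1cccs1)cn2[C@@H]1O[C@H](CO)[C@@H](O)[C@H]1O` is not yet measured; it differs from compound 3 by thiophen-2-yl in place of phenyl on an aromatic carbon, the same change that separates compound 2 from compound 1. For compound 4 the step of an at least 20-fold lower number from compound 3 to compound 4 (1.30 log units; beyond the scatter) is expected, resting on the step of an at least 45-fold lower number from compound 2 to compound 1 (1.65 log units; beyond the scatter). The starting point of that expected step is the limit that compound 3 reaches, > 100000 nM. The value expected for compound 4 is 5000 nM, between 500 nM and 50000 nM.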

Compound 4, half-maximal inhibitory concentration: > 20000 nM
Compound 4: no number, only a limit (the forecaster's own chance of this, stated with the estimate: 25%); middle value at least 4.0-fold (0.60 log units) away from the limit.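

Compound 4 returns only a limit in this assay, one it shares with compound 2: the limit of > 20000 nM in this assay, at which 2 of the 4 values shown sit.

Compound 3 also gives only a limit, > 100000 nM. The steps between the compounds that end at limits cannot be read, so the change to thiophen-2-yl is neither shown to carry over to the methylamino core nor shown to fail there, and the one readable new result is that methylamino in place of methoxy on the thiophene-bearing core gives an at least 45-fold higher number from compound 1 to compound 4 (1.65 log units; beyond the scatter).

The compounds shown leave open whether thiophen-2-yl has any effect on the methylamino core that a number could capture. They also leave open how a dimethylamino or ethoxy group would behave in that place alongside thiophen-2-yl.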